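This account rests on a few compounds, and the source may have more. Where it says the series, first, only, none or still open, it means among the compounds named here.

Compound 1 `COc1ccc(S(=O)(=O)N2CCc3cccc(-c4ccc([N+](=O)[O-])cc4)c32)cc1` gives 53.1 nM in a functional assay on NCI-H460 cells (Homo sapiens) for inhibition, with a stated time of 72 h; a higher number here means a weaker inhibitor, a lower number a stronger inhibitor.
Compound 2 `COc1ccc(S(=O)(=O)N2CCc3cccc(-c4ccc(F)cc4)c32)cc1` gives 95.5 nM in this assay.
Compound 3 `COc1ccc(S(=O)(=O)N2CCc3cccc(-c4ccc(N(C)C)cc4)c32)cc1` gives 556 nM in this assay.

Compound 3 stands at the highest of the three numbers, meaning the weakest inhibition seen here; the nearest step to it is a 5.8-fold higher number from compound 2 to compound 3 (0.77 log units; beyond the scatter), and the furthest is a 10-fold higher number from compound 1 to compound 3 (1.02 log units; beyond the scatter), both beyond the scatter. Compound 4 `COc1ccc(S(=O)(=O)N2CCc3cccc(-c4cccc(F)c4)c32)cc1` differs from compound 3 by 3-fluorophenyl in place of 4-(dimethylamino)phenyl on an aromatic carbon. The step of a 5.8-fold higher number from compound 2 to compound 3 (0.77 log units; beyond the scatter) bears most directly on this change, as it is essentially the same swap run backwards, with the fluorine moved to another position; a 10-fold higher number from compound 1 to compound 3 (1.02 log units; beyond the scatter) points the same way. A lower number is therefore expected, roughly reversing that step: compound 4 is estimated at 120 nM, within 50 nM to 300 nM. This expectation corresponds to a 4.6-fold lower number from compound 3 to compound 4 (0.67 log units; beyond the scatter).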

Compound 4, half-maximal inhibitory concentration: 167 nM
The estimate for compound 4 lay 1.4-fold (0.14 log units) below the measured number; the measured number falls inside the stated range.
By their numbers in this assay, from the lowest: compounds 1, 2 and 4 (each within the scatter of the next, the first and the last beyond it); then compound 3.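

In this assay, moving the fluorine from 4-fluorophenyl to 3-fluorophenyl gives no difference that can be told from the scatter, with a 1.7-fold higher number from compound 2 to compound 4 (0.24 log units; within the scatter). The 3-fluorophenyl group still improves on 4-(dimethylamino)phenyl, with a 3.3-fold lower number from compound 3 to compound 4 (0.52 log units; beyond the scatter), yet it falls short of 4-nitrophenyl, with a 3.1-fold higher number from compound 1 to compound 4 (0.50 log units; beyond the scatter). Nothing available here explains these differences. Still open, as far as these compounds go, is whether the nitro and dimethylamino groups would hold their numbers if placed as the fluorine is in compound 4. From the compounds shown here alone, how a carboxylic acid or an unsubstituted phenyl ring would fare at this position is also open.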